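Swapping Bromo for Nitro on a Chalcone-like Thiazole

The source may report more compounds than this note shows. Statements on the series, on what has been measured and on what is new or still open speak of the compounds shown alone.

Measured compounds:
compound 1, `Nc1nc(N2CCCC2)sc1C(=O)/C=C/c1ccc([N+](=O)[O-])cc1`, 22.4 ug/mL;
compound 2, `Nc1nc(N2CCCCC2)sc1C(=O)/C=C/c1ccc(Br)cc1`, 31.6 ug/mL.

Both compounds were tested in a functional assay on SW480 cells (Homo sapiens) for antiproliferative activity, read by MTT assay, with a stated time of 48 h; on this read-out higher numbers stand for weaker inhibition and lower numbers for stronger inhibition. Compound 1 gives 22.4 ug/mL, and compound 2 gives 31.6 ug/mL. Compound 2 holds the higher of the two numbers, but the gap between compound 2 and compound 1 is within the usual scatter of this assay, so the two compounds cannot be ranked against each other.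

Compound 3, `Nc1nc(N2CCCCC2)sc1C(=O)/C=C/c1ccc([N+](=O)[O-])cc1`, has not yet been measured. It differs from compound 2 in a single place: nitro in place of bromo on an aromatic carbon. Going by the values given here, no measured pair in this set isolates this change, so there is no direct reference for its size. Among the compounds with values here, the only related point is compound 1, which carries the nitro group and gives 22.4 ug/mL, a number within the scatter of compound 2.

Compound 3 is therefore expected to give about 24 ug/mL, with a range from 12 ug/mL to 48 ug/mL. That estimate implies a step of a 1.3-fold lower number from compound 2 to compound 3 (0.12 log units; within the scatter), expected to stay within the scatter rather than marking a real gain or loss.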

Compound 3, half-maximal inhibitory concentration: 25.6 ug/mL
Beside the measured number, compound 3's estimate is 1.1-fold (0.03 log units) below it, and the stated range covers the measured number.
By their numbers in this assay, from the lowest: compounds 1, 3 and 2 (each within the scatter of the next).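

The bromo-to-nitro swap on the aromatic carbon para to a large group can now be read on its own in this assay: the step (a 1.2-fold lower number from compound 2 to compound 3 (0.09 log units; within the scatter)) stays within the scatter, so with the piperidin-1-yl group held fixed, these two groups cannot be told apart at this position. The new compound also isolates a second place on the shared core, and the step for piperidin-1-yl in place of pyrrolidin-1-yl with the nitro group held fixed (a 1.1-fold higher number from compound 1 to compound 3 (0.06 log units; within the scatter)) likewise stays within the scatter, so neither single change separates these compounds in this assay. Nothing in the data explains why either swap leaves the number within the scatter, and no supporting measurement bears on these results.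

Bromo and nitro are only two possible groups, so it remains open whether an amine, a carboxylic acid or a methoxy group at this aromatic carbon would give a step beyond the scatter. Going by these compounds, it is equally open whether a morpholin-4-yl group or an open-chain dimethylamino group, in place of the piperidin-1-yl group, would separate from these compounds.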